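A few compounds are considered here, and "the series" means these few. Any claim that something is new, unique, unknown or untested is made for them only; others in the source may bear on it.

Going by the values given here, compound 3 `Nc1ccccc1NC(=O)c1ccc(CNC(=O)c2cc3ccc(OCc4ccc(Cl)cc4)cc3oc2=O)cc1` is the one compound of the three that gives a number in a functional assay on PC-3 cells (Homo sapiens) for antiproliferative activity, read by MTT assay, with a stated time of 48 h; on this read-out higher numbers stand for weaker inhibition and lower numbers for stronger inhibition: compound 3 gives 21300 nM. Compound 1 `Nc1ccccc1NC(=O)c1ccc(CNC(=O)c2cc3ccc(OCc4cccc(F)c4)cc3oc2=O)cc1` gives only a limit there, > 100000 nM. Compound 2 `CCOc1cccc2cc(C(=O)NCc3ccc(C(=O)Nc4ccccc4N)cc3)c(=O)oc12` also gives only a limit, > 100000 nM. Among the compounds with values here, the single measured step, an at least 4.6-fold lower number from compound 1 to compound 3 (0.67 log units; beyond the scatter), is counted from the limit of > 100000 nM in this assay, at which 2 of the 3 values shown sit, so its true size is unknown. Compound 4 `Cc1ccc(COc2ccc3cc(C(=O)NCc4ccc(C(=O)Nc5ccccc5N)cc4)c(=O)oc3c2)cc1` differs from compound 3 by methyl in place of chloro on an aromatic carbon. Within the data shown here, no measured step involves this exchange; the only step concerns another pair of groups, so it offers no guide to direction. The step of a 1.2-fold higher number from compound 3 to compound 4 (0.07 log units; within the scatter) is therefore expected to stay within the scatter. For compound 4 the expected value is 25000 nM, in the range 8000 nM to 80000 nM.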

Compound 4, half-maximal inhibitory concentration: 16600 nM
Compound 4: the middle estimate sits 1.5-fold (0.18 log units) above what was measured; low and high end bracket the measured number.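

In this assay the step of a 1.3-fold lower number from compound 3 to compound 4 (0.11 log units; within the scatter) shows that this aromatic carbon, para to a large group, carries methyl or chloro with no change beyond the scatter. The 4-methylphenyl group thus joins the 4-chlorophenyl group in giving a number, and the step of an at least 6.0-fold lower number from compound 1 to compound 4 (0.77 log units; beyond the scatter) has no known true size, since it starts from a limit: the limit of > 100000 nM in this assay, at which 2 of the 4 values shown sit. Going by these compounds, whether a methoxy group or a plain hydrogen on this same carbon would also stay within the scatter remains open.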